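Chloro Replacing Hydrogen on a Fused Two-Ring Core

This account rests on a few compounds, and the source may have more. Where it says the series, first, only, none or still open, it means among the compounds named here.

Compound 1, `CCCCCC(CCO)n1cnc2c(N)ncnc21`. In a functional assay on HCT-116 cells (Homo sapiens) for antiproliferative activity, read by MTT assay, with a stated time of 48 h (on this read-out lower numbers stand for stronger inhibition and higher numbers for weaker inhibition), compound 1 gives > 50000 nM, a limit of the assay and not a number.
Compound 2, `CCCCCC(CCO)n1cnc2c(N)nc(Cl)nc21`. In this assay compound 2 gives > 50000 nM, again a limit of the assay.
Compound 3, `CCCCCCCC(CCO)n1cnc2c(Cl)ncnc21`. In this assay compound 3 gives 4160 nM.

Compound 2 is made from compound 1 by one change, (chloro in place of hydrogen on an aromatic carbon). The step that goes with it is a step that the two limits leave unreadable from compound 1 to compound 2; its size cannot be read, which rests on (the limit of > 50000 nM in this assay, at which 2 of the 3 values shown sit). Compound 3 carries a different core, and the difference between the two cores is not broken down here.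

The unmeasured compound 4, `CCCCCCCC(CCO)n1cnc2c(Cl)nc(Cl)nc21`, comes from compound 3 by the same kind of change, (chloro in place of hydrogen on an aromatic carbon). The two places are not the same word for word: in compound 1 the carbon is meta to an amino group, in compound 3 it is meta to a chloro group.

Among the measured compounds shown here, the only readable anchor is the value of compound 3 at 4160 nM, and the one earlier step of this kind is unreadable. An estimate therefore stays close to compound 3. For compound 4 the expected value in this assay is 4000 nM. For compound 4 the expected range runs from 1500 nM to 15000 nM. This estimate means an expected step of a 1.0-fold lower number from compound 3 to compound 4 (0.02 log units; within the scatter).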

Compound 4, half-maximal inhibitory concentration: 12800 nM
For compound 4 the middle estimate is 3.2-fold (0.51 log units) below the measured one, within the range that was stated.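

Where the core already holds one chloro group, putting a second chloro in place of hydrogen, between two ring nitrogen atoms, gives a 3.1-fold higher number from compound 3 to compound 4 (0.49 log units; beyond the scatter) in this assay, which means weaker inhibition of the cells. This is a single pair on a single core, so it shows what the change did here and sets no rule for the series. The earlier step of the same kind cannot be read, and the change therefore cannot be compared from one core to the other, because both compounds of that step sit at a limit and not at a number: the limit of > 50000 nM in this assay, at which 2 of the 4 values shown sit.

The compounds shown leave open whether a fluoro group, a methyl group or a methoxy group in that same place would go the same way as chloro on either core. Also open is how the chain and the group on the core each count in compound 1 and compound 3, which differ in more than one place, with no pair shown to separate the two.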